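A few compounds are considered here, and "the series" means these few. Any claim that something is new, unique, unknown or untested is made for them only; others in the source may bear on it.

Compound 1 `COc1cc2c(cc1OC)C(CC(=O)O)CC2` carries a free acid on its side chain; compound 2 `COc1cc2c(cc1OC)C(CC(=O)NC1CCCC1)CC2` replaces that acid with an amide. In a functional assay on the whole organism (strain Swiss albino) for inhibition, with Mus musculus as the target, in the writhing test, with stated times of 60 min and 15 min, at a dose of 100 mg/kg by the oral route (a lower number here means less inhibition, a higher number more inhibition at the dose given (going by the name of the read-out)), compound 1 gives 44%, and in this assay compound 2 gives 37%. The step of a number 7 percentage points lower from compound 1 to compound 2 (within the scatter) shows that the two readings cannot be told apart. Of the two measured values, compound 2 has the lowest number, with compound 1 nearest and within the scatter of it.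

Compound 3 `COc1cc2c(cc1OC)C(CC(=O)N1CCNCC1)CC2` has not yet been measured. The change from compound 2 is piperazin-1-yl in place of cyclopentylamino on a carbonyl carbon. Within the data shown here, the only measured step that touches the same place is a number 7 percentage points lower from compound 1 to compound 2 (within the scatter), and it stayed within the scatter. On that basis the step of a number 1 percentage points higher from compound 2 to compound 3 (within the scatter) is expected to be small, with no clear direction beyond the scatter. Compound 3 is therefore estimated to give 38% in this assay, with a likely range from 24% to 52%.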

Compound 3, a percentage reported as inhibition, in the whole organism at one dose (the size of the read-out at that dose, not a potency): 68.8%
Beside the measured number, compound 3's estimate is 30.8 percentage points below it; the measured number lies above the stated range.
By their numbers in this assay, from the lowest: compounds 2 and 1 (each within the scatter of the next); then compound 3.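

In this assay, putting piperazin-1-yl on the carbonyl carbon in place of cyclopentylamino gives a number 31.8 percentage points higher from compound 2 to compound 3 (beyond the scatter), so what sits at this place can change the reading, which the earlier step from acid to amide did not show. The two groups hold the same number of heavy atoms, and the count that differs is that piperazin-1-yl has a second ring nitrogen where cyclopentylamino has only carbon in its ring. Replacing the free acid gives a number 24.8 percentage points higher from compound 1 to compound 3 (beyond the scatter), so this amide also reads apart from the acid, though nothing available explains why the number rose.

The compounds shown leave open which feature of piperazin-1-yl goes with the rise. Morpholin-4-yl, with an oxygen in that ring, or piperidin-1-yl, with only one ring nitrogen, would help separate the ring's shape from its second nitrogen.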